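The compounds below may be only part of what the source reports. "The series", "measured", "known", "first", "only" and "open" are said of these compounds alone.

Working notes on the series.

Compound 1, `CCCC[C@H](NC(=O)[C@H](CCCCN)NC(=O)[C@H](CCCNC(=N)N)NC(=O)/C=C/c1ccccc1)C(N)=O`, and compound 2, `CCCC[C@H](NC(=O)[C@H](CCCCN)NC(=O)[C@H](CCCNC(=N)N)NC(=O)c1ccc(/C=C2\SC(=O)N(C3CCCCC3)C2=O)cc1)C(N)=O`, share a peptide-like core and differ in the acyl group on the terminal nitrogen. In an ADME assay for permeability, using PAMPA (on this read-out lower numbers stand for lower permeability and higher numbers for higher permeability), compound 1 gives 1.26 10^-6 cm/s. In this assay compound 2 gives 1.69 10^-6 cm/s. These two numbers are the only ones recorded so far; the gap between them lies within the scatter of the measurement, so neither compound can be set above the other and compound 2 is simply read as one of two closely placed numbers.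

Compound 3, `CCCC[C@H](NC(=O)[C@H](CCCCN)NC(=O)[C@H](CCCNC(=N)N)NC(=O)c1ccc(/C=C2\SC(=O)N(c3ccc(C)cc3)C2=O)cc1)C(N)=O`, has not been measured. Relative to compound 2 the change is 4-methylphenyl in place of cyclohexyl on an amide-type nitrogen in a ring, in words 4-methylphenyl in place of cyclohexyl on an amide-type nitrogen in a ring. For the measured compounds named here, no step of this kind is present among the measured pairs, so nothing speaks to its size or direction. The working expectation is a step of a 1.1-fold lower number from compound 2 to compound 3 (0.05 log units; within the scatter), that is none beyond the scatter. Compound 3 is therefore estimated at 1.5 10^-6 cm/s in this assay, with a range from 0.6 10^-6 cm/s to 3.5 10^-6 cm/s.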

Compound 3, apparent permeability: 0.66 10^-6 cm/s
Compound 3: middle estimate off by 2.3-fold (0.36 log units), on the high side; measured number inside the range.
By their numbers in this assay, from the lowest: compounds 3, 1 and 2 (each within the scatter of the next, the first and the last beyond it).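

In this assay, for the compounds shown here, the amide-type nitrogen in a ring is the first place where a single change gives a step beyond the scatter: 4-methylphenyl in place of cyclohexyl gives a 2.6-fold lower number from compound 2 to compound 3 (0.41 log units; beyond the scatter), a modest step, but one showing that the read-out is not indifferent to the group at this position. Going by these compounds alone, the change replaces a six-membered non-aromatic ring of carbon only with a six-membered aromatic ring of carbon only that carries a methyl group, while neither group has hydrogen-bond donors, hydrogen-bond acceptors or a net charge, so these counted features do not distinguish compound 2 from compound 3. Nothing measured in the series bears on the origin of this step.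

The compounds shown leave open whether the step goes with the aromatic ring or with its methyl group, a question that an unsubstituted phenyl on the same nitrogen would address. Also open, from the compounds shown here alone, is how an open chain such as n-butyl, or a phenyl group bearing an amine or a carboxylic acid, would read at this position in this assay.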